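Urea substituent swap on the heptyl-pentylthio series

This account rests on a few compounds, and the source may have more. Where it says the series, first, only, none or still open, it means among the compounds named here.

Two members of this series have a value in an assay on cells (Macrophage) for inhibition of sterol O-acyltransferase 1 (Mus musculus); a higher number here means a weaker inhibitor, a lower number a stronger inhibitor. Compound 1 `CCCCCCCN(CCCCCSc1[nH]cnc2ncnc1-2)C(=O)NC(C)C` carries an isopropyl urea on one core, and in this assay compound 1 gives 4720 nM. Compound 2 `CCCCCCCN(CCCCCSc1[nH]cnc2nncc1-2)C(=O)Nc1ccc(F)cc1F` carries a 2,4-difluorophenyl urea on a different core, and in this assay compound 2 gives 3310 nM. The two numbers lie within the scatter of one another, so compound 2 does not separate from compound 1 on the evidence at hand; the pair also differs in two places at once, so no single step can be read from it.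

Compound 3 `CCCCCCCN(CCCCCSc1[nH]cnc2nncc1-2)C(=O)NC(C)C` keeps the core of compound 2 and changes only the urea end: isopropyl in place of 2,4-difluorophenyl on an amide-type nitrogen. It is thus the isopropyl urea on the core of compound 2. Within the data shown here, no measured pair isolates this change. Given that compound 1, which carries the same isopropyl urea, gives 4720 nM, the step from compound 2 to compound 3 is expected to be small and, if anything, toward a slightly higher number, as a 1.3-fold higher number from compound 2 to compound 3 (0.10 log units; within the scatter). Compound 3 is therefore estimated at 4200 nM, with a range of 1500 nM to 12000 nM.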

Compound 3, half-maximal inhibitory concentration in the sterol O-acyltransferase 1 assay: 4350 nM
The estimate for compound 3 lay 1.0-fold (0.02 log units) below the measured number, and the stated range covers the measured number.
By their numbers in the sterol O-acyltransferase 1 assay, from the lowest: compounds 2, 3 and 1 (each within the scatter of the next).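

In the sterol O-acyltransferase 1 assay, the urea end now stands as an isolated change: isopropyl in place of 2,4-difluorophenyl on the amide-type nitrogen gives a 1.3-fold higher number from compound 2 to compound 3 (0.12 log units; within the scatter), so on this core the loss of the aromatic ring and its two fluorines leaves the two compounds unseparated. The core exchange is isolated as well, and with a 1.1-fold lower number from compound 1 to compound 3 (0.04 log units; within the scatter) it does not separate the two isopropyl ureas either, so neither single change yet has a readable effect on the number. In a physicochemical assay for lipophilicity (a higher number here means a more lipophilic compound, a lower number a more polar compound), compound 2 gives 5.6 and compound 3 gives 5. Lipophilicity does separate compound 2 and compound 3, so for this pair it falls with the inhibition number staying within the scatter: the measured partition coefficient of compound 2, 5.6, and of compound 3, 5, a number 0.60 log units lower (beyond the scatter)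

All three compounds lie within the scatter of the next in the sterol O-acyltransferase 1 assay, so the compounds shown identify no feature that governs inhibition in this series. Still open, on these data alone, is whether a more different urea substituent, such as one carrying an amine or a carboxylic acid, or a shorter chain in place of the heptyl group, would give a step beyond the scatter.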